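Swapping a Fluorophenyl for Pyridinyl in a Cytotoxicity Series

The source may hold more compounds than are shown below. What is called first, only, known or untested is meant among the compounds shown, and "the series" means these compounds.

Of the compounds shown here, three with a shared core have been tested in an ADME assay on L6 cells (Rattus norvegicus) for cytotoxicity, read by resazurin assay, with a stated time of 72 h; on this read-out higher numbers stand for weaker inhibition and lower numbers for stronger inhibition. Compound 1 `OC(c1ccc(Cl)cc1)(c1cncnc1)c1cccc(F)c1` gives only a limit in this assay, > 100000 nM. Compound 3 `OC(c1cccnc1)(c1cccs1)c1ccc(Cl)cc1F` likewise reaches only a limit, > 100000 nM. For the measured compounds named here, compound 2 `NC(c1ccc(Cl)cc1)(c1cccnc1)c1ccccc1Cl` is the one member with an actual number, 76000 nM. Compound 1 therefore stands at the limit of > 100000 nM in this assay, at which 2 of the 3 values shown sit, so its cytotoxicity is too weak for this assay to put a number on it.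

The unmeasured compound 4 `OC(c1ccc(Cl)cc1)(c1cccnc1)c1cncnc1` differs from compound 1 in a single place: pyridin-3-yl in place of 3-fluorophenyl on a saturated chain carbon bound to two aromatic carbons and an oxygen on a saturated carbon. Going by the values given here, no pair of measured compounds differs in just one place, so no measured step shows how such a swap plays out here. The three values together point to weak cytotoxicity throughout the set, and nothing in them suggests a shift beyond the scatter of this assay. Compound 4 is therefore expected at 100000 nM, between 50000 nM and 300000 nM, with a fair chance that this assay once more reports only a limit. The step that this expectation means, a number no higher from compound 1 to compound 4 (the limit leaves the size open), is expected to lie within the usual scatter.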

Compound 4, half-maximal inhibitory concentration: > 100000 nM
Compound 4 gave a limit, no number; the forecaster's own chance of this, stated with the estimate: 70%; the middle value lies on the limit itself.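

Compound 1 and compound 4 each give only a limit in this assay, so no step can be read for pyridin-3-yl in place of 3-fluorophenyl; both sit at the assay's limit: the limit of > 100000 nM in this assay, at which 3 of the 4 values shown sit. The compounds shown leave open whether this swap changes cytotoxicity at all, and in which direction.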